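Chlorine moved on the arylpiperazine of compound 1

A few compounds are considered here, and "the series" means these few. Any claim that something is new, unique, unknown or untested is made for them only; others in the source may bear on it.

Measured compounds:
compound 1 `CCCc1nc(-c2ccccc2)c(CNCCN2CCN(c3ccc(Cl)cc3)CC2)o1` with 55.8%
compound 2 `CCCc1nc(-c2ccccc2)c(CNCCCN2CCN(c3cccc(C(F)(F)F)c3)CC2)o1` with 51.6%

Of the compounds shown here, two have been tested in an assay on HEK293 cells for inhibition of Voltage-dependent T-type calcium channel subunit alpha-1G (Homo sapiens), read by fluorescence, tested at 10 uM; a higher number here means more inhibition at the concentration tested (going by the name of the read-out), a lower number less inhibition. Compound 1 gives 55.8%, and compound 2 gives 51.6%; the two numbers fall within the usual scatter of each other, so no order between them can be claimed. Compound 3 `CCCc1nc(-c2ccccc2)c(CNCCN2CCN(c3cccc(Cl)c3)CC2)o1` is not yet measured. It differs from compound 1 in one place: 3-chlorophenyl in place of 4-chlorophenyl on an amine nitrogen in a ring. Among the measured compounds shown here, no measured pair shows this kind of change, so the expected step of a number 3.8 percentage points lower from compound 1 to compound 3 (within the scatter) is none beyond the scatter. Compound 3 is therefore estimated at 52%, in a range from 35% to 68%.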

Compound 3, a percentage reported as inhibition, at one concentration (the size of the read-out at that concentration, not a potency): 51.2%
Beside the measured number, compound 3's estimate is 0.8 percentage points above it; the measured number falls inside the stated range.
By their numbers in this assay, from the lowest: compounds 3, 2 and 1 (each within the scatter of the next).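

In this assay, among the compounds shown here, placing 3-chlorophenyl in place of 4-chlorophenyl on the amine nitrogen in the ring gives a number 4.6 percentage points lower from compound 1 to compound 3 (within the scatter) and so provides the first comparison that differs in one place. Within this series, moving the chlorine on this phenyl ring therefore shows no difference that can be claimed, and the two chlorophenyl compounds cannot be ordered. Nothing measured here bears on why the two placements read alike. The compounds shown leave open whether a methoxy group or a nitrile in place of the chlorine would give a step beyond the scatter.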